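Thiourea aryl swap on a benzamide scaffold

The compounds below may be only part of what the source reports. "The series", "measured", "known", "first", "only" and "open" are said of these compounds alone.

The series shares a benzamide core, with compound 2 `Cc1ccc(CNC(=S)Nc2ccc(C(=O)Nc3ccccc3N)cc2)cn1` carrying a thiourea linked to a (6-methylpyridin-3-yl)methyl group. In a functional assay on MDA-MB-231 cells (Homo sapiens) for cytotoxicity, read by MTT assay, with a stated time of 72 h (a lower number here means a stronger inhibitor, a higher number a weaker inhibitor), compound 2 gives 63000 nM. Of the two numerical values shown, that of compound 2 is the higher; its nearest neighbour is the urea compound 1 `Nc1ccccc1NC(=O)c1ccc(NC(=O)NCc2ccc(Cl)nc2)cc1`, which in this assay gives 34000 nM, a gap that stays within the usual scatter, so the two cannot be ranked against each other. Compound 3 `Nc1ccccc1NC(=O)c1ccc(CNC(=O)c2cc3cccnc3[nH]2)cc1` reaches only a limit of the assay, > 100000 nM, and is thus reported as a limit rather than a number; see (the limit of > 100000 nM in this assay, at which 1 of the 3 values shown sits).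

The unmeasured compound 4 `Nc1ccccc1NC(=O)c1ccc(NC(=S)NCc2ccccc2F)cc1` differs from compound 2 in one place: 2-fluorophenyl in place of 6-methylpyridin-3-yl on a saturated chain carbon bound to an amide-type nitrogen. The thiourea and the benzamide core are kept. Among the compounds with values here, no measured pair in this set isolates such a change, so there is no direct guide to its effect.

Given that every numerical value here is weak and the two numbers lie within scatter of each other, compound 4 is expected to stay in the same region, with a step from a 1.4-fold lower number from compound 2 to compound 4 (0.15 log units; within the scatter) that amounts to no more than the scatter. Compound 4 is estimated at 45000 nM, within a range from 15000 nM to 130000 nM.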

Compound 4, half-maximal inhibitory concentration: > 100000 nM
Compound 4: only a limit was reported (the forecaster's own chance of this, stated with the estimate: 25%); at least 2.2-fold (0.34 log units) between middle value and limit.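

In this assay, within the data shown here, replacing 6-methylpyridin-3-yl with 2-fluorophenyl on a saturated chain carbon bound to an amide-type nitrogen gives the only single-place step in this set, read as an at least 1.5-fold higher number from compound 2 to compound 4 (0.20 log units; that floor lies within the scatter). The value of compound 4 is a limit and not a number, so this step has a floor but no known size: the limit of > 100000 nM in this assay, at which 2 of the 4 values shown sit. With the thiourea and the shared core kept, the step gives no sign of a gain from this exchange, which replaces a group with one hydrogen-bond acceptor by a group with none, and it does not establish a loss beyond the scatter.

As far as these compounds go, whether the true step exceeds the scatter remains open, as does the question of which part of the exchange matters: the loss of the ring nitrogen, the loss of the methyl or the arrival of the fluorine. The compounds shown do not tell how an unsubstituted phenyl, a pyridin-3-yl without the methyl or a 2-chlorophenyl would stand at this position, and any of these could help separate those contributions.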